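Trimming the Biaryl: From Compound 3 to Compound 4

A few compounds are considered here, and "the series" means these few. Any claim that something is new, unique, unknown or untested is made for them only; others in the source may bear on it.

Measured so far in a functional assay on DLD-1 cells (Homo sapiens) for antiproliferative activity, read by CellTiter-Glo, with a stated time of 72 h; on this read-out higher numbers stand for weaker inhibition and lower numbers for stronger inhibition:
compound 1 `Cc1cc(C)c(S(=O)(=O)N2CCN(C3CN4CCC3CC4)CC2)c(C)c1` gives 84 nM
compound 2 `Cc1cc(C)c(S(=O)(=O)N2CCC(N3CCC(O)CC3)CC2)c(C)c1` gives 106 nM
compound 3 `Cc1cc(C)cc(-c2cccc(S(=O)(=O)N3CCC(N4CCC(C)CC4)CC3)c2)c1` gives 41 nM

Among these three, compound 3 has the lowest number, and its gaps to compound 1 and compound 2 both lie beyond the usual scatter, so it is the strongest inhibitor seen here. Compound 4 `CC1CCN(C2CCN(S(=O)(=O)c3cccc(Cl)c3)CC2)CC1` differs from compound 3 in one place: chloro in place of 3,5-dimethylphenyl on an aromatic carbon. Among the compounds with values here, a group of 8 heavy atoms with its own aromatic ring is replaced by a single chlorine atom, and nothing measured so far shows what that costs. I expect the number in this assay to rise by a step of a 7.3-fold higher number from compound 3 to compound 4 (0.86 log units; beyond the scatter), clearly beyond the scatter. Compound 4 is estimated at 300 nM, with a likely range from 80 nM to 1200 nM.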

Compound 4, half-maximal inhibitory concentration: > 5000 nM
Compound 4: no number, only a limit (the forecaster's own chance of this, stated with the estimate: 5%); at least 16-fold (1.22 log units) between middle value and limit.
By their numbers in this assay, from the lowest: compound 3; then compounds 1 and 2 (each within the scatter of the next). At a limit, above all of these: compound 4.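

In this assay, putting chloro in place of 3,5-dimethylphenyl on this aromatic carbon gives an at least 120-fold higher number from compound 3 to compound 4 (2.08 log units; beyond the scatter), the first one-place change seen in this series, and it shows that activity depends strongly on what sits here. Compound 4 reaches only a limit and not a number, so the true size of this step stays unknown: the limit of > 5000 nM in this assay, at which 1 of the 4 values shown sits.

The compounds shown leave open what a plain phenyl, a pyridine ring or a cyclohexyl group would do here. It therefore remains unclear whether the aromatic ring or its two methyl groups matter more.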